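Dropping the Trifluoromethyl Group: What to Expect for Compound 4

The source may report more compounds than this note shows. Statements on the series, on what has been measured and on what is new or still open speak of the compounds shown alone.

Measured so far in a functional assay on HepG2 cells (Homo sapiens) for antiproliferative activity, read by MTT assay, with a stated time of 72 h; a lower number here means a stronger inhibitor, a higher number a weaker inhibitor:
Compound 1 `FC(F)(F)c1ccc(COc2cccc(Nc3ncnc4cc5c(cc34)OCCOCCOCCO5)c2)cc1` gives 34000 nM.
Compound 2 `FC(F)(F)c1ccc(COc2ccc(Nc3ncnc4cc5c(cc34)OCCOCCOCCOCCO5)cc2)cc1` gives 3340 nM.
Compound 3 `c1ccc(COc2ccc(Nc3ncnc4cc5c(cc34)OCCOCCOCCOCCO5)cc2)cc1` gives 11900 nM.

Compound 2 and compound 3 share one core and differ only in hydrogen in place of trifluoromethyl on an aromatic carbon; that change produced a 3.6-fold higher number from compound 2 to compound 3 (0.55 log units; beyond the scatter). The difference between the core of compound 1 and the core of compound 2 is not broken down here, so their values are simply read as they stand, with compound 1 carrying the highest number of the three.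

Compound 4 `c1ccc(COc2cccc(Nc3ncnc4cc5c(cc34)OCCOCCOCCO5)c2)cc1` relates to compound 1 exactly as compound 3 relates to compound 2: the change is hydrogen in place of trifluoromethyl on an aromatic carbon, the same change at the same place. Among the measured compounds shown here, the step expected from it is a 3.2-fold higher number from compound 1 to compound 4 (0.51 log units; beyond the scatter), resting on the single measured step of a 3.6-fold higher number from compound 2 to compound 3 (0.55 log units; beyond the scatter). Compound 4 is therefore estimated to give 110000 nM, expected to fall between 45000 nM and 280000 nM.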

Compound 4, half-maximal inhibitory concentration: > 100000 nM
Compound 4 was reported as a limit; the forecaster's own chance of this, stated with the estimate: 35%; the middle value lies beyond the limit too.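

In this assay compound 4 gives > 100000 nM, which is a limit of the assay and not a number. Putting hydrogen in place of trifluoromethyl gave an at least 2.9-fold higher number from compound 1 to compound 4 (0.46 log units; beyond the scatter), and setting this beside the earlier step shows the change carrying over in direction: the same change on two cores in this assay, a 3.6-fold higher number (0.55 log units; beyond the scatter) from compound 2 to compound 3 and an at least 2.9-fold higher number (0.46 log units; beyond the scatter) from compound 1 to compound 4; the limit leaves it open whether they differ. So the number rose on both cores, but the true size of the step on the core of compound 1 stays unknown, and two cores make no general rule for the series.

The compounds shown leave open how a chlorine atom, a nitrile or a methoxy group at the same place would compare with trifluoromethyl and hydrogen. They also leave open whether the same step would hold on any further core.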